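Thiophen-2-yl to 4-chloro-2-fluorophenyl: an expected gain

This account rests on a few compounds, and the source may have more. Where it says the series, first, only, none or still open, it means among the compounds named here.

Three compounds sharing one core have been measured:

compound 1, `Cc1ccc(-c2nnc(COc3cnn(C(C)(C)C)c(=O)c3Cl)o2)cc1`, gives 19.9 ug/mL in a functional assay on the whole organism for inhibition, with Mythimna separata as the target, with a stated time of 5 days; on this read-out lower numbers stand for an effect already at smaller amounts and higher numbers for an effect only at larger amounts of compound;
compound 2, `CC(C)(C)n1ncc(OCc2nnc(-c3cccs3)o2)c(Cl)c1=O`, reaches only a limit of the assay, > 300 ug/mL;
compound 3, `CC(C)(C)n1ncc(OCc2nnc(-c3ccc(C(F)(F)F)cc3)o2)c(Cl)c1=O`, gives 34.1 ug/mL.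

Compound 2 thus stands at the top edge of the numbers shown: no number could be read for it, only (the limit of > 300 ug/mL in this assay, at which 1 of the 3 values shown sits). The step to compound 4, `CC(C)(C)n1ncc(OCc2nnc(-c3ccc(Cl)cc3F)o2)c(Cl)c1=O`, is 4-chloro-2-fluorophenyl in place of thiophen-2-yl on an aromatic carbon. Among the measured compounds shown here, two measured steps bear on it. an at least 15-fold higher number from compound 1 to compound 2 (1.17 log units; beyond the scatter) shows what a thiophen-2-yl ring does in place of a 4-methylphenyl ring; run in the reverse direction, as here, it points to a large drop in the number. a 1.7-fold higher number from compound 1 to compound 3 (0.23 log units; within the scatter) lies within the scatter, so a phenyl ring carrying other small groups is expected to land near compounds 1 and 3. A large downward step, beyond the scatter, is therefore expected: an at least 10-fold lower number from compound 2 to compound 4 (1.00 log units; beyond the scatter). Compound 4 is expected to give about 30 ug/mL, within a range from 10 ug/mL to 120 ug/mL.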

Compound 4, half-maximal effective concentration: 10.4 ug/mL
The estimate for compound 4 lay 2.9-fold (0.46 log units) above the measured number; measured number inside the range.
By their numbers in this assay, from the lowest: compounds 4, 1 and 3 (each within the scatter of the next, the first and the last beyond it). At a limit, above all of these: compound 2.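

Among the compounds shown here, the change shows that a phenyl ring with two halogens on this carbon, and not only one with a single group such as methyl or trifluoromethyl, gives a readable number in this assay: an at least 28-fold lower number from compound 2 to compound 4 (1.46 log units; beyond the scatter). Exchanging one substituted phenyl for another here makes no clear difference, since the step is a 1.9-fold lower number from compound 1 to compound 4 (0.28 log units; within the scatter). Among the four compounds, the thiophen-2-yl ring is thus the only group that gives no number, and for compound 2 the result is a limit of the assay: the limit of > 300 ug/mL in this assay, at which 1 of the 4 values shown sits.

For the compounds shown here, it remains open whether the chlorine or the fluorine of compound 4 matters more, as no compound carries only one of them. From the compounds shown here alone, it is also open whether another five-membered ring, such as furan-2-yl, would behave like thiophen-2-yl, and how a phenyl ring carrying an amine or a carboxylic acid would fare.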